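A longer sulfonyl chain on the shared core

This account rests on a few compounds, and the source may have more. Where it says the series, first, only, none or still open, it means among the compounds named here.

Compound 1, `CS(=O)(=O)NNc1nonc1/C(=N/O)Nc1ccc(F)c(Br)c1`: > 800 nM.
Compound 2, `N=S1(=O)CC(Nc2nonc2/C(=N/O)Nc2ccc(F)c(Br)c2)C1`: 53 nM.
Compound 3, `NNS(=O)(=O)CCNc1nonc1/C(=N/O)Nc1ccc(F)c(Br)c1`: > 800 nM.

In an assay on HeLa cells for inhibition of Indoleamine 2,3-dioxygenase 1 (Homo sapiens), read by spectrophotometry, with a stated time of 24 h (on this read-out higher numbers stand for an effect only at larger amounts of compound and lower numbers for an effect already at smaller amounts), compound 1 gives > 800 nM, which is a limit of the assay and not a number; (the limit of > 800 nM in this assay, at which 2 of the 3 values shown sit). Compound 2 gives 53 nM. Compound 3 gives > 800 nM, again a limit. Among the measured compounds shown here, the one readable step is an at least 15-fold lower number from compound 1 to compound 2 (1.17 log units; beyond the scatter); in the other direction, an at least 15-fold higher number from compound 2 to compound 3 (1.17 log units; beyond the scatter). Between the two limits, a step that the two limits leave unreadable from compound 1 to compound 3.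

Compound 4, `CN(C)S(=O)(=O)CCCNc1nonc1/C(=N/O)Nc1ccc(F)c(Br)c1`, differs from compound 1 in one place: 3-(dimethylsulfamoyl)propyl in place of methanesulfonamido on a nitrogen on an aromatic ring. For the measured compounds named here, the step that bears most directly on it is the one from compound 1 to compound 3, where a chain-bearing sulfonyl group likewise replaced methanesulfonamido on the same nitrogen and the value stayed at the limit. The only large gain seen, from compound 1 to compound 2, came with the four-membered ring, which compound 4 lacks. Compound 4 is therefore expected to stay at or beyond the limit, with no readable step in this assay; the estimated step from compound 1 is a step that the limit leaves unreadable from compound 1 to compound 4. The estimate for compound 4 is 1500 nM, with a range from 400 nM to 6000 nM.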

Compound 4, half-maximal effective concentration: 20 nM
For compound 4 the middle estimate is 75-fold (1.88 log units) above the measured one; the whole stated range lies above it.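

In this assay, the open 3-(dimethylsulfamoyl)propyl chain gives a large gain on this nitrogen without any ring: an at least 40-fold lower number from compound 1 to compound 4 (1.60 log units; beyond the scatter), and an at least 40-fold lower number from compound 3 to compound 4 (1.60 log units; beyond the scatter), so a sulfonyl-bearing chain in this place does not by itself leave a compound at the limit. The four-membered ring of compound 2 is not required either, as the comparison with the open chain shows a 2.7-fold lower number from compound 2 to compound 4 (0.42 log units; beyond the scatter), a modest step in favour of the open chain. The values of compound 1 and compound 3 are each a limit of the assay and not a number: the limit of > 800 nM in this assay, at which 2 of the 4 values shown sit.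

The step from compound 3 to compound 4 changes the chain length and the end group together, so the compounds shown do not tell whether the gain follows the propyl chain, the two methyl groups on the sulfonamide nitrogen, or both. Also open, from the compounds shown here alone, is how the value would respond to 2-(dimethylsulfamoyl)ethyl, a longer chain, or an amine or carboxylic acid at the end of the propyl chain.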